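The source may hold more compounds than are shown below. What is called first, only, known or untested is meant among the compounds shown, and "the series" means these compounds.

The measured compounds in a functional assay on T-24 cells (Homo sapiens) for antiproliferative activity, read by MTT assay, with a stated time of 48 h; on this read-out lower numbers stand for stronger inhibition and higher numbers for weaker inhibition:

compound 1, `CCOc1ccc(NC(=O)Nc2cccc(CNc3nccnc3Cl)c2)cc1`: 9080 nM
compound 2, `COc1ccc(NC(=O)Nc2cccc(CNc3nccnc3Cl)c2)cc1`: 9820 nM
compound 3, `O=C(Nc1cccc(CNc2nccnc2Cl)c1)Nc1ccc(Cl)cc1Cl`: 5740 nM

Among these three numbers compound 1 stands second highest. Its nearest neighbour is compound 2, reached by a 1.1-fold higher number from compound 1 to compound 2 (0.03 log units; within the scatter), a change that does not leave the scatter. Its furthest neighbour is compound 3, reached by a 1.6-fold lower number from compound 1 to compound 3 (0.20 log units; within the scatter), which also stays inside the scatter. The third pair behaves the same way: a 1.7-fold lower number from compound 2 to compound 3 (0.23 log units; within the scatter). In short, all three measured compounds sit within the scatter of one another, and no ordering among them can be read from the numbers.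

The account now turns to compound 4, `O=C(Nc1cccc(CNc2nccnc2Cl)c1)Nc1ccccc1Cl`, which is not yet measured. Compared with compound 1 the change is 2-chlorophenyl in place of 4-ethoxyphenyl on an amide-type nitrogen. Within the data shown here, the steps that bear on this are those that exchange an alkoxyphenyl for a chlorinated phenyl on the same amide-type nitrogen, namely a 1.6-fold lower number from compound 1 to compound 3 (0.20 log units; within the scatter) and a 1.7-fold lower number from compound 2 to compound 3 (0.23 log units; within the scatter); both lean toward a lower number, but both remain within the scatter. A step of similar size, if any, is therefore expected here, leaning lower but not clearly beyond the scatter. On that basis compound 4 is estimated at 7000 nM, with a range from 3000 nM to 16000 nM. This estimate corresponds to a 1.3-fold lower number from compound 1 to compound 4 (0.11 log units; within the scatter).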

Compound 4, half-maximal inhibitory concentration: 6680 nM
Beside the measured number, compound 4's estimate is 1.0-fold (0.02 log units) above it; the range from low to high includes it.
By their numbers in this assay, from the lowest: compounds 3, 4, 1 and 2 (each within the scatter of the next).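

In this assay, the exchange of an alkoxyphenyl for 2-chlorophenyl on the amide-type nitrogen now gives a 1.4-fold lower number from compound 1 to compound 4 (0.13 log units; within the scatter) and a 1.5-fold lower number from compound 2 to compound 4 (0.17 log units; within the scatter), so a phenyl group carrying a single chloro joins the 2,4-dichlorophenyl of compound 3 in staying within the scatter of both alkoxyphenyl compounds. The earlier compounds shown here could not separate the two chloro groups of compound 3, but the new pair gives a 1.2-fold higher number from compound 3 to compound 4 (0.07 log units; within the scatter), which shows that taking away one chloro makes no readable difference on this read-out. No measurement is at hand that would explain this flat response at the amide-type nitrogen.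

All four compounds carry only alkoxy or chloro groups on this phenyl ring, so the compounds shown leave open whether an amine, a carboxylic acid or a longer alkoxy chain there would give a step beyond the scatter. They also leave open whether this position matters at all for the read-out, or whether changes to the shared core, such as an amine in place of its chloro, would move the numbers more.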